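A methyl added to the nitrogen of compound 2

The source may hold more compounds than are shown below. What is called first, only, known or untested is meant among the compounds shown, and "the series" means these compounds.

In a functional assay on DU-145 cells (Homo sapiens) for antiproliferative activity, read by sulforhodamine B assay, with a stated time of 48 h (on this read-out lower numbers stand for stronger inhibition of growth and higher numbers for weaker inhibition of growth), compound 1 `CCCNc1nc(Nc2ccc(OC)cc2)nc2ccccc12` gives 4080 nM and compound 2 `CNc1nc(Nc2ccc(OC)cc2)nc2ccccc12` gives 14300 nM, the higher of the two numbers. Compound 3 `CNc1nc(N(C)c2ccc(OC)cc2)nc2ccccc12` carries methyl in place of hydrogen on a nitrogen on an aromatic ring. For the measured compounds named here, only one measured step offers a guide, and it lies at a different place: a 3.5-fold higher number from compound 1 to compound 2 (0.54 log units; beyond the scatter). It loses carbon and the number rises, so a similarly modest move towards a lower number is tentatively expected in this assay. The expected step is a 2.4-fold lower number from compound 2 to compound 3 (0.38 log units; beyond the scatter). For compound 3 the estimated value is 6000 nM, with an expected range of 1500 nM to 30000 nM.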

Compound 3, concentration for 50% growth inhibition: 24300 nM
Estimate against measurement, compound 3: 4.1-fold (0.61 log units) below; the range from low to high includes it.
By their numbers in this assay, from the lowest: compound 1; then compounds 2 and 3 (each within the scatter of the next).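

In this assay, methyl in place of hydrogen on this nitrogen on an aromatic ring gives a 1.7-fold higher number from compound 2 to compound 3 (0.23 log units; within the scatter) so this pair cannot be told apart. For the compounds shown here, this is the first look at that nitrogen, and a single added methyl there brings no clear difference in growth inhibition. Nothing available here explains this result.
On these data alone, whether a longer chain or a benzyl group on this nitrogen would also leave the number within the scatter remains open. So does whether the same methyl would behave alike alongside the longer chain of compound 1.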